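A few compounds are considered here, and "the series" means these few. Any claim that something is new, unique, unknown or untested is made for them only; others in the source may bear on it.

Working notes on the cinnamamide series measured in a functional assay on MCF7 cells (Homo sapiens) for antiproliferative activity, read by MTT assay, with a stated time of 48 h; a higher number here means a weaker inhibitor, a lower number a stronger inhibitor.

Of the compounds shown here, three carry a number so far. Compound 1 `Cc1ccc(-c2nnc(NC(=O)/C=C/c3ccc(C(F)(F)F)cc3)s2)cc1` gives 1.1 ug/mL. Compound 2 `O=C(/C=C/c1ccccc1)Nc1nnc(-c2ccc(Br)cc2)s1` gives 1.5 ug/mL. Compound 3 `Cc1ccc(/C=C/C(=O)Nc2nnc(-c3ccc(Br)cc3)s2)cc1` gives 1.32 ug/mL, which is the second highest of the three numbers; its nearest neighbour is compound 2, its furthest compound 1, and both gaps fall within the usual scatter, so no order among the three can be claimed.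

Among the compounds with values here, the one single-point step measured, a 1.1-fold lower number from compound 2 to compound 3 (0.06 log units; within the scatter), shows methyl in place of hydrogen on an aromatic carbon making no difference beyond the scatter.

Compound 4 `O=C(/C=C/c1ccc(C(F)(F)F)cc1)Nc1nnc(-c2ccc(Br)cc2)s1` is next to be measured. Its change from compound 3 is trifluoromethyl in place of methyl on an aromatic carbon. Within the data shown here, no measured pair shows trifluoromethyl in place of methyl directly. Compound 1 carries trifluoromethyl at the same place and gives 1.1 ug/mL, close to the number for compound 3, but compound 1 also differs elsewhere, so this is only an indication. The bearing step, from compound 2 to compound 3, was within the scatter. The expected step is therefore a 1.1-fold lower number from compound 3 to compound 4 (0.04 log units; within the scatter), with no direction beyond the scatter.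

Compound 4 is estimated at 1.2 ug/mL, expected to lie between 0.6 ug/mL and 2.4 ug/mL in this assay.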

Compound 4, half-maximal inhibitory concentration: 1.58 ug/mL
Compound 4: the middle estimate sits 1.3-fold (0.12 log units) below what was measured; the range from low to high includes it.
By their numbers in this assay, from the lowest: compounds 1, 3, 2 and 4 (each within the scatter of the next).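

In this assay the position on the aromatic carbon para to a large group now has a direct reading for trifluoromethyl: a 1.2-fold higher number from compound 3 to compound 4 (0.08 log units; within the scatter), and a 1.1-fold higher number from compound 2 to compound 4 (0.02 log units; within the scatter). Together with a 1.1-fold lower number from compound 2 to compound 3 (0.06 log units; within the scatter), this means that hydrogen, methyl and trifluoromethyl at this place cannot be told apart in this series, although trifluoromethyl brings more heavy atoms than methyl. Within the data shown here, compound 4 also gives a first one-place reading at the other site of change, with trifluoromethyl held constant: a 1.4-fold higher number from compound 1 to compound 4 (0.16 log units; within the scatter), for bromo in place of methyl on an aromatic carbon, so this change also stays inside the scatter, and no information on hand accounts for the flat response at either place.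

The compounds shown leave open whether a group of another kind at the trifluoromethyl position, such as an amine, a carboxylic acid or a longer chain, would move the number beyond the scatter. They also leave open whether the same flat picture would hold at the bromo position with any group other than methyl.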